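The source may report more compounds than this note shows. Statements on the series, on what has been measured and on what is new or still open speak of the compounds shown alone.

Compound 1, `CCCCCCCCCCCCCCN(NC(=O)COC)C(=O)CCCCCCCCC`, tested in a functional assay on K562 cells (Homo sapiens) for antiproliferative activity, read by resazurin assay, with a stated time of 72 h (a lower number here means a stronger inhibitor of growth, a higher number a weaker inhibitor of growth), gives > 110000 nM, which is a limit of the assay rather than a number.
Compound 2, `CCCCCCCCCCN(NC(=O)COC)C(=O)CCCCCCCCC`, tested in this assay, gives 97300 nM.
Compound 3, `CCCCCCCCCCCCCCNNC(=O)COC`, tested in this assay, gives 66200 nM.

Compound 4, `CCCCCCCCCCNNC(=O)COC`, has not yet been tested in this assay. It is related to compound 3 in the same way that compound 2 is related to compound 1: in both cases the chain on the nitrogen is shortened.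

From compound 1 to compound 2 the change is hydrogen in place of butyl on a saturated chain carbon, ten or more bonds along the chain from an amide-type nitrogen. The step it produced was an at least 1.1-fold lower number from compound 1 to compound 2 (0.05 log units; that floor lies within the scatter). The true size of that step cannot be pinned down, because the limit of > 110000 nM in this assay, at which 1 of the 3 values shown sits, means that compound 1 has no exact number, only a floor.

From compound 3 to compound 4 the change is hydrogen in place of butyl on a saturated chain carbon, ten or more bonds along the chain from an amine nitrogen. How the core of compound 3 differs from the core of compound 1 is not broken down here; the two differ in more than one place. The surroundings of the change also differ: in compound 1 the chain belongs to an amide-type nitrogen, in compound 3 to an amine nitrogen. It is therefore the same kind of change, not the same change.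

Given the small and uncertain step seen in an at least 1.1-fold lower number from compound 1 to compound 2 (0.05 log units; that floor lies within the scatter), the expected step from compound 3 to compound 4 is a 1.2-fold lower number from compound 3 to compound 4 (0.08 log units; within the scatter), which would stay within the scatter. Compound 4 is estimated at 55000 nM, expected to lie between 25000 nM and 130000 nM.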

Compound 4, concentration for 50% growth inhibition: 167000 nM
Estimate against measurement, compound 4: 3.0-fold (0.48 log units) below, and the stated range ends below it.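

In this assay, taking the chain on the amine nitrogen from its longer to its shorter form gives a 2.5-fold higher number from compound 3 to compound 4 (0.40 log units; beyond the scatter), a modest but real loss of growth inhibition on this core. The same kind of change on the core with the amide-type nitrogen did not give a step of this kind, so in this series the effect of shortening the chain cannot simply be carried from one core to the other: the same change on two cores in this assay, an at least 1.1-fold lower number (0.05 log units; that floor lies within the scatter) from compound 1 to compound 2 and a 2.5-fold higher number (0.40 log units; beyond the scatter) from compound 3 to compound 4, at least 2.8-fold (0.45 log units) apart, beyond the scatter of two such steps. Among these compounds, this rests on only one pair of compounds per core, and it shows neither the true size of the step on the amide-type core nor any reason why the two cores part ways, since compound 1 carries a limit of the assay and not a number: the limit of > 110000 nM in this assay, at which 1 of the 4 values shown sits.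

The compounds shown leave open whether the difference between the cores holds at other chain lengths, for instance with a dodecyl chain or a chain longer than any here. They also leave open how growth inhibition would respond if the chain carried a carboxylic acid or an amine, on either core.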